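Dichlorophenyl for Dimethylaminophenyl on a Thiourea Core

The source may report more compounds than this note shows. Statements on the series, on what has been measured and on what is new or still open speak of the compounds shown alone.

Measured in a functional assay, with a stated time of 20 min, tested at 2 uM; a higher number here means a stronger effect of the compound at the concentration tested, a lower number a weaker effect:
compound 1 `COc1cc(/C=C/C(=O)C2=C(/C=C/c3ccc(O)c(OC)c3)NC(=O)NC2c2ccc(N(C)C)cc2)ccc1O`: 28.2%
compound 2 `COc1cc(/C=C/C(=O)C2=C(/C=C/c3ccc(O)c(OC)c3)NC(=O)NC2c2c(Cl)cccc2Cl)ccc1O`: 11.2%
compound 3 `COc1cc(/C=C/C(=O)C2=C(/C=C/c3ccc(O)c(OC)c3)NC(=S)NC2c2ccc(N(C)C)cc2)ccc1O`: 32.3%

Compound 3 gives the highest number of the three, but its gap to compound 1 lies within the scatter, while compound 2 lies beyond the scatter below it. The difference between the core of compound 1 and the core of compound 3 is not broken down here. The change from compound 1 to compound 2 is 2,6-dichlorophenyl in place of 4-(dimethylamino)phenyl on a saturated ring carbon, which gave a number 17 percentage points lower from compound 1 to compound 2 (beyond the scatter). Compound 4 `COc1cc(/C=C/C(=O)C2=C(/C=C/c3ccc(O)c(OC)c3)NC(=S)NC2c2c(Cl)cccc2Cl)ccc1O` has not yet been measured in this assay. It arises from compound 3 by the same change, (2,6-dichlorophenyl in place of 4-(dimethylamino)phenyl on a saturated ring carbon). Because a number 17 percentage points lower from compound 1 to compound 2 (beyond the scatter) is the only precedent shown, a step of about that size is expected here. For compound 4 this expectation is a number 17.3 percentage points lower from compound 3 to compound 4 (beyond the scatter). Compound 4 is accordingly estimated at 15%, with a likely range from 5% to 28%.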

Compound 4, a percentage reported as activity, at one concentration (the size of the read-out at that concentration, not a potency): 15%
For compound 4 middle estimate and measured number coincide at the digits printed, and the stated range covers the measured number.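

In this assay 2,6-dichlorophenyl in place of 4-(dimethylamino)phenyl on the saturated ring carbon gave a number 17.3 percentage points lower from compound 3 to compound 4 (beyond the scatter) on the second core. The change therefore carried over from one core to the other at much the same size: the same change on two cores in this assay, a number 17 percentage points lower (beyond the scatter) from compound 1 to compound 2 and a number 17.3 percentage points lower (beyond the scatter) from compound 3 to compound 4, 0.3 percentage points apart, within the scatter of two such steps. Among the compounds shown here, this rests on only two pairs and one pair of groups, so it does not show that the step would hold on any further core or for any other group, and it gives no reason for the drop.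

The compounds shown leave open how an unsubstituted phenyl, a carboxylic acid or a longer chain on that ring carbon would compare. They also leave open whether the two chlorine atoms act together or singly.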